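Moving the chlorine around a benzyl ring

The compounds below may be only part of what the source reports. "The series", "measured", "known", "first", "only" and "open" are said of these compounds alone.

Measured so far:
Compound 1, `CCOC(=O)CCCSc1nc2ccccc2n1CC(=O)O`, 4410 nM
Compound 2, `O=C(O)Cn1c(SCc2cccc(Cl)c2)nc2ccccc21`, 186 nM

Among the measured compounds shown here, in an assay on HEK293 cells for displacement of a labelled ligand from prostaglandin D2 receptor 2 (Homo sapiens) (on this read-out lower numbers stand for stronger inhibition and higher numbers for weaker inhibition), compound 2 gives the lowest of the two numbers; its only neighbour is compound 1, and the step of a 24-fold lower number from compound 1 to compound 2 (1.37 log units; beyond the scatter) shows that exchanging the ester-bearing chain for a 3-chlorophenyl group changed the read-out a great deal. Compound 3, `O=C(O)Cn1c(SCc2ccccc2Cl)nc2ccccc21`, keeps everything in compound 2 except the position of the chlorine on the benzyl ring: 2-chlorophenyl in place of 3-chlorophenyl on a saturated chain carbon bound to a sulfur. For the measured compounds named here, no measured step bears directly on this kind of change; the one step known concerns the replacement of a whole chain by an aryl group, not a shift of a substituent within an aryl group. The 3-chlorophenyl and 2-chlorophenyl groups are the same size and carry the same atoms, so the expectation is a step of a 1.3-fold higher number from compound 2 to compound 3 (0.13 log units; within the scatter) that stays close to the scatter. Compound 3 is therefore estimated at 250 nM in this assay, with a range from 60 nM to 1000 nM.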

Compound 3, half-maximal inhibitory concentration: 370 nM
For compound 3 the middle estimate is 1.5-fold (0.17 log units) below the measured one; the range from low to high includes it.
By their numbers in this assay, from the lowest: compounds 2 and 3 (each within the scatter of the next); then compound 1.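

In this assay moving the chlorine gives a 2.0-fold higher number from compound 2 to compound 3 (0.30 log units; within the scatter) and so, on a saturated chain carbon bound to a sulfur, the 2-chlorophenyl and 3-chlorophenyl groups cannot be told apart here. The large change seen earlier on leaving the ester-bearing chain also appears with the second chlorine placement, as a 12-fold lower number from compound 1 to compound 3 (1.08 log units; beyond the scatter) shows, so that change is not tied to the 3-chlorophenyl group alone. No outside evidence bears on why the two placements read alike.

Still open, on these data alone, is whether the chlorine matters at all, which a plain phenyl group at the same place would test. Equally open, as far as these compounds go, is whether bromine or a methoxy group in the chlorine's place would read like these two compounds.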